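Chloro on the pyridine ring and microsomal stability

The source may report more compounds than this note shows. Statements on the series, on what has been measured and on what is new or still open speak of the compounds shown alone.

Compound 1 `COc1cccc(S(=O)(=O)/C=C/c2ccccn2)c1` gives 74% in an ADME assay on microsomes from liver (Homo sapiens) for metabolic stability, read by LC-MS, using NADPH, with stated times of 5 min and 30 min, tested at 1 uM; a lower number here means that less of the compound is left, a higher number that more of the compound is left. Compound 2 `COc1cccc(S(=O)(=O)/C=C/c2cccc(Cl)n2)c1` carries chloro in place of hydrogen on an aromatic carbon and in this assay gives 34%; the step is a number 40 percentage points lower from compound 1 to compound 2 (beyond the scatter). Compound 3 `COc1ccc(S(=O)(=O)/C=C/c2ccccn2)cc1` is built from the same atoms as compound 1, joined differently; the difference between the two cores is not broken down here. In this assay compound 3 gives 56%, which stands between the numbers of compound 1 and compound 2, beyond the scatter of each.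

Compound 4 `COc1ccc(S(=O)(=O)/C=C/c2ccc(Cl)cn2)cc1` has not yet been measured in this assay. It differs from compound 3 by chloro in place of hydrogen on an aromatic carbon. This is the same kind of change as that from compound 1 to compound 2, but not the same: there the chlorine enters next to the ring nitrogen, meta to a large group, whereas in compound 4 it enters two atoms from the ring nitrogen, para to a large group. A fall is expected because a number 40 percentage points lower from compound 1 to compound 2 (beyond the scatter) was large, though the different place leaves the size uncertain. The step expected is a number 26 percentage points lower from compound 3 to compound 4 (beyond the scatter). Compound 4 is estimated at 30%, likely between 12% and 50%.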

Compound 4, percent of the compound remaining: 6%
The estimate for compound 4 lay 24 percentage points above the measured number, and the stated range ends above it.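

In this assay, chloro in place of hydrogen on an aromatic carbon gives a number 50 percentage points lower from compound 3 to compound 4 (beyond the scatter). Set beside the earlier step, the change carries over from the core of compound 1 to the core of compound 3 in direction and, within the scatter, in size: the same change on two cores in this assay, a number 40 percentage points lower (beyond the scatter) from compound 1 to compound 2 and a number 50 percentage points lower (beyond the scatter) from compound 3 to compound 4, 10 percentage points apart, within the scatter of two such steps. The two pairs differ in where the chlorine stands as well as in the core, however, and they do not show how much of each step belongs to the place or to the core, or whether the same fall would appear on a further core.

The compounds shown leave open whether the fall belongs to chloro itself or would also follow with fluoro, methyl, methoxy or an amine on the same carbon. Also open, as far as these compounds go, is what chloro would do on the core of compound 1 at the place it holds in compound 4, and on the core of compound 3 at the place it holds in compound 2.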